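A few compounds are considered here, and "the series" means these few. Any claim that something is new, unique, unknown or untested is made for them only; others in the source may bear on it.

In a physicochemical assay for solubility, read by nephelometry, measured as kinetic solubility, at pH 2.0 (a lower number here means a less soluble compound, a higher number a more soluble compound), the measured compounds read as follows

Compound 1 `CC(C)(C)c1cc(C(=O)Nc2ccccn2)n(Cc2ccccc2)n1` gives 25 ug/mL
Compound 2 `Cn1nc(C(C)(C)C)cc1C(=O)Nc1nc(CN)cs1` gives > 100 ug/mL
Compound 3 `NCc1csc(NC(=O)c2cc3ccccc3n2Cc2ccccc2)n1` gives 25 ug/mL

On these numbers, compound 1 at 25 ug/mL stands level with compound 3 at 25 ug/mL in this assay with no change beyond the scatter. Compound 2 reads > 100 ug/mL and that reading is a limit of the assay, not a number.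

Compound 4 `CNCc1csc(NC(=O)c2cc(C(C)(C)C)nn2Cc2ccccc2)n1` has not yet been measured. It carries 4-((methylamino)methyl)-1,3-thiazol-2-yl in place of pyridin-2-yl on an amide-type nitrogen, and 4-((methylamino)methyl)-1,3-thiazol-2-yl in place of pyridin-2-yl on an amide-type nitrogen gives the full count of that change.

Within the data shown here, no measured pair isolates this change, so the expectation rests on the three readings alone. The upward lean comes from compound 2, whose limit of > 100 ug/mL shows the top of the assay can be reached. The restraint on size comes from compound 3 at 25 ug/mL in this assay as a reading no different from that of compound 1. A small upward move, about the size of the scatter, is expected as a 1.8-fold higher number from compound 1 to compound 4 (0.26 log units; within the scatter) in this estimate. The estimated value for compound 4 is 45 ug/mL with an expected range from 18 ug/mL to 100 ug/mL in this assay when it is read.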

Compound 4, solubility: 25 ug/mL
Compound 4: middle estimate off by 1.8-fold (0.26 log units), on the high side; the range from low to high includes it.
By their numbers in this assay, from the lowest: compounds 1, 3 and 4 (each within the scatter of the next). At a limit, above all of these: compound 2.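

In this assay, 4-((methylamino)methyl)-1,3-thiazol-2-yl in place of pyridin-2-yl on an amide-type nitrogen gives no change at the digits printed from compound 1 to compound 4 (within the scatter). This is the first pair among the compounds shown that differs in this one place, and the reading of this change now rests on a direct comparison. The entering group is larger by the counts and carries a hydrogen-bond donor that pyridin-2-yl lacks, yet the two compounds cannot be told apart in this read-out.

Among these compounds, compound 2 gives > 100 ug/mL, which is a limit of the assay and not a number, and it forms no one-place pair with compound 1 or compound 4: the limit of > 100 ug/mL in this assay, at which 1 of the 4 values shown sits. Still open, as far as these compounds go, is whether a carboxylic acid or a longer chain in place of the methylamino part would move the reading at this pH.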